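The source may hold more compounds than are shown below. What is called first, only, known or untested is meant among the compounds shown, and "the series" means these compounds.

Measured compounds:
compound 1, `COc1ccccc1-n1nc([C@@H]2CCO[C@@H](C(C)C)C2)cc1-c1ccc(Cl)cc1`: 26%
compound 2, `COc1ccccc1-n1nc([C@H]2C[C@@H](C)O[C@@H](C)C2)cc1-c1ccc(Cl)cc1`: 64%

In an ADME assay on microsomes from liver (Homo sapiens) for metabolic stability, with a stated time of 10 min (a higher number here means that more of the compound is left, a lower number that less of the compound is left), compound 1 gives 26% and compound 2 gives 64%. For the measured compounds named here, compound 2 thus stands highest of the two numbers measured; its nearest neighbour is compound 1, and the single step on record, a number 38 percentage points higher from compound 1 to compound 2 (beyond the scatter), came with 2,6-dimethyloxan-4-yl in place of 2-isopropyloxan-4-yl on an aromatic carbon.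

Compound 3, `COc1ccccc1-n1nc(C2C[C@H](C)O[C@@H](C)C2)cc1-c1ccc(Cl)cc1`, keeps the same atoms and bonds as compound 2 and differs only in how the saturated ring is drawn: the two compounds have the same atoms and bonds; at least one stereo element is drawn with a configuration in one of them and without one in the other: 2 of 3 stereo elements differ; a stereocentre at a saturated ring carbon is drawn r in compound 2 and without a configuration in compound 3; a stereocentre at a saturated ring carbon is drawn R in compound 2 and S in compound 3. Going by the values given here, no measured step concerns such a change of stereo elements; the one step available, from compound 1 to compound 2, changed the groups themselves and so gives no guidance on direction here. The expectation is therefore no step beyond the scatter, with the wider uncertainty that an untested kind of change brings, so that compound 3 is expected to give 55% in this assay, within 30% to 80%, that is an expected a number 9 percentage points lower from compound 2 to compound 3 (within the scatter).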

Compound 3, percent of the compound remaining: 40%
Beside the measured number, compound 3's estimate is 15 percentage points above it; measured number inside the range.
By their numbers in this assay, from the lowest: compound 1; then compound 3; then compound 2.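

In this assay, the way the saturated ring is drawn proves enough on its own to move the number: with atoms and bonds unchanged, there is a number 24 percentage points lower from compound 2 to compound 3 (beyond the scatter). The earlier step changed the groups themselves, and compound 3 now shows that the result of having 2,6-dimethyloxan-4-yl in place of 2-isopropyloxan-4-yl depends on the stereo elements, since the listed step is a number 14 percentage points higher from compound 1 to compound 3 (beyond the scatter), still beyond the scatter but modest rather than large. The change cannot be pinned on a single stereocentre, because two stereo elements differ at once, and the one fact that bears on it is this: the fact that one of compounds 2 and 3 is drawn with a defined configuration and the other without, at the place where they differ

The compounds shown leave open which of the two changed stereo elements carries the step, and where compound 3's number would lie with its undrawn centre given a defined configuration. They also leave open what an amine or a hydroxyl group on the saturated ring would do to the percentage remaining.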